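This account rests on a few compounds, and the source may have more. Where it says the series, first, only, none or still open, it means among the compounds named here.

In a functional assay for antagonist activity at thromboxane A2 receptor (Rattus norvegicus) (a higher number here means weaker binding, a lower number tighter binding), the measured compounds are:

- compound 1, `O=C(O)CC/C=C\CO[C@H]1[C@@H](OCc2ccc(-c3ccccc3)cc2)CC[C@@H]1N1CCCCC1`, giving 31.6 nM; 50.1 nM (2 entries)
- compound 2, `O=C(O)CC/C=C\CO[C@H]1C(OCc2ccc(-c3ccccc3)cc2)CC[C@@H]1N1CCCCCC1`, giving 25.1 nM
- compound 3, `O=C(O)CC/C=C\CO[C@H]1C(OCc2ccc(-c3ccccc3CCO)cc2)CC[C@@H]1N1CCCCCC1`, giving 31.6 nM

Among these, compound 2 has the lowest of the two single numbers, and compound 3 sits close to it: the step of a 1.3-fold higher number from compound 2 to compound 3 (0.10 log units; within the scatter) stays within the scatter, so no order between them can be read. Compound 1 contributes two entries rather than one number, and the several entries of compound 1 in this assay, 31.6 nM; 50.1 nM (2 entries) shows how far repeated measurements of one compound can drift in this assay.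

Compound 4, `O=C(O)CC/C=C\CO[C@H]1C(OCc2ccc(-c3ccccc3O)cc2)CC[C@@H]1N1CCCCCC1`, has not yet been measured. It departs from compound 2 by hydroxy in place of hydrogen on an aromatic carbon. For the measured compounds named here, the only measured step bearing on this change is a 1.3-fold higher number from compound 2 to compound 3 (0.10 log units; within the scatter), where a 2-hydroxyethyl group entering the same kind of aromatic carbon left the number essentially unchanged. With a smaller hydroxy group entering instead, a step of similar size is expected: a 1.2-fold higher number from compound 2 to compound 4 (0.08 log units; within the scatter), none beyond the scatter. Compound 4 is therefore estimated at 30 nM, with a range from 12 nM to 80 nM.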

Compound 4, dissociation constant: 20 nM
Compound 4: middle estimate off by 1.5-fold (0.18 log units), on the high side, and the stated range covers the measured number.
By their numbers in this assay, from the lowest: compounds 4, 2 and 3 (each within the scatter of the next).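

Replacing phenyl with 2-hydroxyphenyl adds one oxygen atom at this aromatic carbon, ortho to a large group, and in this assay it gives a 1.3-fold lower number from compound 2 to compound 4 (0.10 log units; within the scatter). Exchanging 2-hydroxyethyl for hydroxy at the same kind of carbon gives a 1.6-fold lower number from compound 3 to compound 4 (0.20 log units; within the scatter), so two oxygen-bearing groups of different length now sit here without a readable change from the unsubstituted compound or from each other. Repeat measurements of a single compound spread about as far as these gaps: the several entries of compound 1 in this assay, 31.6 nM; 50.1 nM (2 entries)

Still open, going by these compounds, is whether an amine, a carboxylic acid or a longer chain ending in hydroxy at this carbon would move the number beyond the scatter. The compounds shown also do not tell whether hydroxy on other carbons of this ring would leave the number just as unchanged.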